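Cyclopentyl replacing cyclopropyl: cytotoxicity expectation for compound 4

A few compounds are considered here, and "the series" means these few. Any claim that something is new, unique, unknown or untested is made for them only; others in the source may bear on it.

Measured compounds:
- compound 1 `N#Cc1ccc(Nc2nccc(NC3CCCCC3)n2)cc1`: 7330 nM
- compound 2 `Cc1cnc(Nc2ccc(C#N)cc2)nc1NC1CCCC1`: 170 nM
- compound 3 `N#Cc1ccc(Nc2nccc(NC3CC3)n2)cc1`: 1190 nM

In an ADME assay on MT4 cells (Homo sapiens) for cytotoxicity, read by MTT assay (on this read-out lower numbers stand for higher toxicity in this test and higher numbers for lower toxicity in this test), compound 3 gives 1190 nM, the second highest of the three numbers. Where compound 3 carries a cyclopropyl, compound 1 carries a cyclohexyl, and in this assay compound 1 gives 7330 nM; the step of a 6.2-fold lower number from compound 1 to compound 3 (0.79 log units; beyond the scatter) lies beyond the scatter. Compound 2, which carries a cyclopentyl and also differs at the shared core, gives 170 nM.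

Compound 4 `N#Cc1ccc(Nc2nccc(NC3CCCC3)n2)cc1` is not yet measured. It differs from compound 3 by cyclopentyl in place of cyclopropyl on a nitrogen on an aromatic ring. Among the compounds with values here, the only step bearing on this change is a 6.2-fold lower number from compound 1 to compound 3 (0.79 log units; beyond the scatter), where a smaller ring on that nitrogen gave a lower number; the cyclopentyl of compound 4 sits between those two ring sizes. The value of compound 2, which shares the cyclopentyl, points the same way. Compound 4 is therefore expected to give a number below that of compound 3, a step of about a 2.0-fold lower number from compound 3 to compound 4 (0.30 log units; within the scatter), with the estimate for compound 4 being 600 nM, in a range from 180 nM to 2500 nM.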

Compound 4, half-maximal cytotoxic concentration: 9130 nM
Compound 4: middle estimate off by 15-fold (1.18 log units), on the low side, and the stated range ends below it.
By their numbers in this assay, from the lowest: compound 2; then compound 3; then compounds 1 and 4 (each within the scatter of the next).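

In this assay, the ring on this nitrogen does not follow a simple order of size. Cyclopentyl in place of cyclopropyl gives a 7.7-fold higher number from compound 3 to compound 4 (0.88 log units; beyond the scatter), while cyclopentyl in place of cyclohexyl gives a 1.2-fold higher number from compound 1 to compound 4 (0.10 log units; within the scatter), so these two larger rings cannot be told apart here and compound 3 alone stands lower. Hydrogen in place of methyl on an aromatic carbon gives a 54-fold higher number from compound 2 to compound 4 (1.73 log units; beyond the scatter), so the low number of compound 2 goes with its methyl rather than with the cyclopentyl it shares with compound 4.

The compounds shown leave open where a cyclobutyl or an open chain such as isopropyl on this nitrogen would fall, and whether the methyl has a similar effect alongside cyclopropyl or cyclohexyl. Nothing shown here explains either step.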